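The compounds below may be only part of what the source reports. "The series", "measured", "known", "first", "only" and "open" are said of these compounds alone.

Compound 1 `Cc1cc(C)cc(Cc2ccc3c(NCCCNCc4ccco4)ccnc3c2)c1` and compound 2 `c1ccc(Cc2ccc3c(NCCCNCc4ccco4)ccnc3c2)cc1` share one core and differ only in the group on a saturated chain carbon bound to an aromatic carbon. In an ADME assay on HepG2 cells (Homo sapiens) for cytotoxicity, read by luminescence, CellTiter-Glo and ATP content, with a stated time of 72 h (a higher number here means that more compound is needed for the effect, a lower number that less compound is needed), compound 1 gives 6270 nM, the lowest of the two numbers measured; compound 2 gives 16000 nM, and the step of a 2.6-fold higher number from compound 1 to compound 2 (0.41 log units; beyond the scatter). Compound 3 `COc1ccc(F)cc1CNCCCNc1ccnc2cc(Cc3cc(C)cc(C)c3)ccc12` keeps the 3,5-dimethylphenyl of compound 1 and instead alters the group on a saturated chain carbon bound to an amine nitrogen: 5-fluoro-2-methoxyphenyl in place of furan-2-yl on a saturated chain carbon bound to an amine nitrogen. Among the measured compounds shown here, no measured step touches this part of the molecule, so there is no direct guide. Because a 2.6-fold higher number from compound 1 to compound 2 (0.41 log units; beyond the scatter) was only modest for a change of an aryl group elsewhere, the expected step of a 1.0-fold lower number from compound 1 to compound 3 (0.02 log units; within the scatter) is small, in either direction, and may stay within the scatter. Compound 3 is therefore expected to give about 6000 nM, between 2500 nM and 15000 nM.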

Compound 3, half-maximal effective concentration: 940 nM
Compound 3: middle estimate off by 6.4-fold (0.81 log units), on the high side; the measured number lies below the stated range.
By their numbers in this assay, from the lowest: compound 3; then compound 1; then compound 2.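

In this assay, the place on a saturated chain carbon bound to an amine nitrogen proves able to move the number: swapping furan-2-yl for 5-fluoro-2-methoxyphenyl gives a 6.7-fold lower number from compound 1 to compound 3 (0.82 log units; beyond the scatter) in the series. That step runs the opposite way to a 2.6-fold higher number from compound 1 to compound 2 (0.41 log units; beyond the scatter) and is the larger of the two, so less compound is needed for the cytotoxic effect once the new group is in place, although the group's counts of hydrogen-bond donors and acceptors stay the same. No measurement here accounts for the step.

The compounds shown cannot separate the fluorine, the methoxy group and the change from a five-membered to a six-membered ring, which an unsubstituted phenyl in this place would begin to do. From the compounds shown here alone, whether the phenyl in place of 3,5-dimethylphenyl has the same effect alongside the new group also remains open.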